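From a Methoxyamide to a Plain Amide

The compounds below may be only part of what the source reports. "The series", "measured", "known", "first", "only" and "open" are said of these compounds alone.

Measured compounds:
compound 1, `CONC(=O)[C@@H]1CC=C(CCC=C(C)C)C[C@H]1c1ccccc1`, 2700 nM
compound 2, `CC1(C)CCCC2=C1C[C@@H](C(=O)O)[C@H](c1ccccc1)C2`, limit of > 23000 nM
compound 3, `CON(C)C(=O)[C@H]1CC2=C(CCCC2(C)C)C[C@@H]1c1ccccc1`, limit of > 23000 nM

Of the compounds shown here, three have been tested in an assay on isolated protein for inhibition of Apoptosis regulator Bcl-2 (Homo sapiens), read by fluorescence polarization, with stated times of 5 min and 10 min; on this read-out higher numbers stand for weaker inhibition and lower numbers for stronger inhibition. Among the compounds with values here, compound 1, `CONC(=O)[C@@H]1CC=C(CCC=C(C)C)C[C@H]1c1ccccc1`, gives 2700 nM, and it is the only compound of the three with a measured number. Compound 2, `CC1(C)CCCC2=C1C[C@@H](C(=O)O)[C@H](c1ccccc1)C2`, reaches only the limit of the assay at > 23000 nM. Compound 3, `CON(C)C(=O)[C@H]1CC2=C(CCCC2(C)C)C[C@@H]1c1ccccc1`, likewise stops at the limit of > 23000 nM. Compound 1 therefore stands alone with a real value, while the other two sit at the limit of > 23000 nM in this assay, at which 2 of the 3 values shown sit, so no difference between them can be read.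

Compound 4, `CC(C)=CCCC1=CC[C@@H](C(N)=O)[C@H](c2ccccc2)C1`, has not yet been measured. It differs from compound 1 in one place: hydrogen in place of methoxy on an amide-type nitrogen. The carbonyl and the rest of the shared core are unchanged; only the group on the amide-type nitrogen is exchanged.

Within the data shown here, no pair of measured compounds differs in exactly one place, so no single step is available to guide the expectation. The change from methoxyamino to amino is small in count, and the estimate for this assay is a step of a 1.5-fold higher number from compound 1 to compound 4 (0.17 log units; within the scatter), slightly toward weaker inhibition and close to the scatter. Compound 4 is thus expected to give about 4000 nM, with a likely range from 1000 nM to 15000 nM.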

Compound 4, inhibition constant: > 23000 nM
Compound 4: only a limit was reported; the forecaster's own chance of this, stated with the estimate: 20%; middle value at least 5.7-fold (0.75 log units) from the limit.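

In this assay, replacing the methoxy on the amide-type nitrogen with hydrogen gives an at least 8.5-fold higher number from compound 1 to compound 4 (0.93 log units; beyond the scatter), so this small change, with the carbonyl and the shared core left as they are, weakens inhibition beyond the scatter. Within the data shown here, this is the first step in the set that changes only one place, and it shows that the measurable inhibition of compound 1 depends on the methoxy at this position. Compound 4 is reported only as a limit, so the full size of the loss cannot be read, and it joins the compounds that have no real number: the limit of > 23000 nM in this assay, at which 3 of the 4 values shown sit.

The compounds shown do not reveal whether the whole methoxy is needed or only part of it, a question that a methyl, a hydroxy or a longer ethoxy on the same nitrogen would begin to answer. They also leave open whether any such group could bring inhibition below that of compound 1, and whether the effect of the methoxy would hold on a different core.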